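A few compounds are considered here, and "the series" means these few. Any claim that something is new, unique, unknown or untested is made for them only; others in the source may bear on it.

Series notes, a functional assay on KB cells (Homo sapiens) for cytotoxicity, read by spectrophotometry and crystal violet staining; a higher number here means a weaker inhibitor, a lower number a stronger inhibitor.

Measured so far:
compound 1 `COC(=N)c1c(Cl)n(C2O[C@H](CO)[C@@H](O)[C@H]2O)c2cc(Cl)c(Cl)cc12` gives 50000 nM in this assay
compound 2 `CO/N=C/c1c(Cl)n(C2O[C@H](CO)[C@@H](O)[C@H]2O)c2cc(Cl)c(Cl)cc12` gives 70000 nM in this assay

Compound 2 carries the highest of the two numbers in this assay; its nearest neighbour is compound 1, and the step between the two is a 1.4-fold higher number from compound 1 to compound 2 (0.15 log units; within the scatter), within the scatter. For the measured compounds named here, that is the only measured step, and it exchanges one group for another on an aromatic carbon of the shared core, leaving the group on the double-bonded nitrogen untouched.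

Compound 3 `COC(=O)N/N=C/c1c(Cl)n(C2O[C@H](CO)[C@@H](O)[C@H]2O)c2cc(Cl)c(Cl)cc12` is not yet measured. Its change from compound 2 is (methoxycarbonyl)amino in place of methoxy on a double-bonded nitrogen. Going by the values given here, no measured pair alters this position, so the single measured step, a 1.4-fold higher number from compound 1 to compound 2 (0.15 log units; within the scatter), bears on it only as a sign that the one substitution tried near this part of the core moved the number within the scatter. The expected step in this assay is therefore no change at the digits printed from compound 2 to compound 3 (within the scatter), with no direction beyond the scatter claimed. Compound 3 is estimated at 70000 nM in this assay, with a range from 20000 nM to 200000 nM.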

Compound 3, half-maximal inhibitory concentration: 20000 nM
Compound 3: middle estimate off by 3.5-fold (0.54 log units), on the high side; measured number inside the range.
By their numbers in this assay, from the lowest: compound 3; then compounds 1 and 2 (each within the scatter of the next).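

In this assay, for the compounds shown here, the group on the double-bonded nitrogen now shows an effect on the number: (methoxycarbonyl)amino in place of methoxy gives a 3.5-fold lower number from compound 2 to compound 3 (0.54 log units; beyond the scatter) and is the first step to lie beyond the scatter. Compound 3 also separates from compound 1, with a 2.5-fold lower number from compound 1 to compound 3 (0.40 log units; beyond the scatter) for the exchange of the whole group on the aromatic carbon, whereas compounds 1 and 2 could not be told apart. Both steps are modest, compound 3 still reads 20000 nM, and no evidence is available that accounts for them.

A single replacement at this position cannot show whether the lower number follows the added carbonyl, the added nitrogen or the greater size of the group, and a plain amino group or an acetylamino group on the double-bonded nitrogen would begin to separate these. Nor do the compounds shown tell whether a longer chain in place of the terminal methoxy of the (methoxycarbonyl)amino group, such as ethoxy, would lower the number further or return it to the level of compound 2.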